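The compounds below may be only part of what the source reports. "The series", "measured", "known", "first", "only" and "open" are said of these compounds alone.

Measured compounds:

Compound 1, `NC(=O)c1c(NC(=O)c2ccccc2Br)sc2c1CCN(C(=S)Nc1ccccc1Br)C2`: 13700 nM
Compound 2, `NC(=O)c1c(NC(=O)c2ccccc2C(F)(F)F)sc2c1CCN(C(=S)Nc1ccccc1Br)C2`: 23900 nM
Compound 3, `Cc1ccccc1C(=O)Nc1sc2c(c1C(N)=O)CCN(C(=S)Nc1ccccc1Br)C2`: > 50000 nM

The value given for compound 3 is a limit of the assay and not a number. All three were tested in a functional assay on MKN-74 cells (Homo sapiens) for antiproliferative activity, with a stated time of 24 h; a lower number here means a stronger inhibitor, a higher number a weaker inhibitor. In this assay compound 1 gives 13700 nM, and compound 2 gives 23900 nM. Between these two the change is trifluoromethyl in place of bromo on an aromatic carbon, and the step is a 1.7-fold higher number from compound 1 to compound 2 (0.24 log units; within the scatter). Between compound 1 and compound 3 the change is methyl in place of bromo on an aromatic carbon, with a step of an at least 3.6-fold higher number from compound 1 to compound 3 (0.56 log units; beyond the scatter). From compound 2 to compound 3 the step is an at least 2.0-fold higher number from compound 2 to compound 3 (0.32 log units; beyond the scatter). Both steps that reach compound 3 can only be given as lower bounds because of the limit of > 50000 nM in this assay, at which 1 of the 3 values shown sits.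

Compound 4, `Cc1ccccc1C(=O)Nc1sc2c(c1C(N)=O)CCN(C(=S)Nc1ccccc1C(F)(F)F)C2`, has not yet been measured. Among the compounds with values here, it differs from compound 3 by trifluoromethyl in place of bromo on an aromatic carbon, the same change as the one from compound 1 to compound 2, at the same place on the ring. The two cores differ as described by methyl in place of bromo on an aromatic carbon. Since the earlier step of this change was a 1.7-fold higher number from compound 1 to compound 2 (0.24 log units; within the scatter), a step of similar size is expected here, written as a step that the limit leaves unreadable from compound 3 to compound 4. Because compound 3 already sits at the limit > 50000 nM, the estimate for compound 4 is 85000 nM, expected to lie between 40000 nM and 200000 nM, most likely reported again only as a limit.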

Compound 4, half-maximal inhibitory concentration: 17400 nM
Beside the measured number, compound 4's estimate is 4.9-fold (0.69 log units) above it; the measured number lies below the stated range.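

In this assay, the swap of bromo for trifluoromethyl did not give the same result on the two cores: the same change on two cores in this assay, a 1.7-fold higher number (0.24 log units; within the scatter) from compound 1 to compound 2 and an at least 2.8-fold lower number (0.45 log units; beyond the scatter) from compound 3 to compound 4, at least 5.0-fold (0.70 log units) apart, beyond the scatter of two such steps. The new step is an at least 2.8-fold lower number from compound 3 to compound 4 (0.45 log units; beyond the scatter), and it is only a bound, as the value of compound 3 is a limit and not a number: the limit of > 50000 nM in this assay, at which 1 of the 4 values shown sits. So a step seen on one core cannot simply be carried over to another in this series, but the two pairs do not show what sets the steps apart, since they differ in two ways: the cores differ by methyl in place of bromo, and the swap from compound 3 to compound 4 falls on the (2-bromophenyl)amino group, while the swap from compound 1 to compound 2 falls on the other aromatic ring that carries a bromo.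

The compounds shown leave open whether the same swap on the (2-bromophenyl)amino group would give a similar step on the core of compound 1, which would separate these two differences. They also leave open how other groups at this place, such as a methoxy group, an amine or a carboxylic acid, would compare with bromo and trifluoromethyl.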